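This account rests on a few compounds, and the source may have more. Where it says the series, first, only, none or still open, it means among the compounds named here.

Of the compounds shown here, three built on one shared core have been tested in a functional assay on CCRF-CEM cells (Homo sapiens) for inhibition, read by sulforhodamine B assay, with a stated time of 48 h; on this read-out higher numbers stand for weaker inhibition of growth and lower numbers for stronger inhibition of growth. Compound 1 `COc1cc(C)cc(-c2c(-c3ccnc(-c4ccc(N(C)C)cc4)c3)cnn2CC#N)c1` reaches only a limit of the assay, not a number, at > 100000 nM. Compound 2 `COc1cc(C)cc(-c2nn(CC#N)cc2-c2ccnc(-c3ccc(N(C)C)cc3)c2)c1` likewise gives a limit of the assay rather than a number, > 100000 nM. Compound 3 `COc1cc(C)cc(-c2nn(CC#N)cc2-c2ccc(-c3cccc(C(C)=O)c3)nc2)c1` also stops at a limit of the assay, > 100000 nM. Compound 2 therefore stands exactly where the whole set stands: the limit of > 100000 nM in this assay, at which 3 of the 3 values shown sit, so no step between measured compounds can be read, and the numbers shown do not set any of the three apart from the others.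

Compound 4 `Cc1cc(O)cc(-c2nn(CC#N)cc2-c2ccnc(-c3ccc(N(C)C)cc3)c2)c1` has not yet been measured. The change from compound 2 to compound 4 is hydrogen in place of methyl on an oxygen on an aromatic ring; cut one bond further out it reads methoxy to hydroxy, on the 3-methoxy-5-methylphenyl that becomes 3-hydroxy-5-methylphenyl. Because every measured value sits at the limit of > 100000 nM in this assay, at which 3 of the 3 values shown sit, a step of this size is expected to change nothing beyond the scatter, and the expected step of a number no higher from compound 2 to compound 4 (the limit leaves the size open) is accordingly flat. Compound 4 is thus expected to give about 100000 nM in this assay, within a range of 30000 nM to 300000 nM, most probably again as a limit.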

Compound 4, concentration for total growth inhibition: > 100000 nM
Compound 4: no number, only a limit (the forecaster's own chance of this, stated with the estimate: 80%); the middle value lies on the limit itself.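

Among the compounds shown here, compound 4, like compound 2, gives only a limit of the assay and not a number in this assay, so no step from compound 2 to compound 4 can be read. The compounds shown leave open what effect, if any, a change on the shared core has on growth inhibition, since all of them stand at one value: the limit of > 100000 nM in this assay, at which 4 of the 4 values shown sit.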